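The source may hold more compounds than are shown below. What is called first, only, known or untested is meant among the compounds shown, and "the series" means these compounds.

Notes on the shared core of compound 1 `O=C(O)CC/C=C\CC1COC(c2ccc(Cl)cc2Cl)OC1c1cccnc1`. In a functional assay for inhibition, with Homo sapiens as the target (a higher number here means weaker binding, a lower number tighter binding), compound 1 gives 891 nM; compound 2 `O=C(O)CC/C=C\CC1COC(c2ccco2)OC1c1cccnc1` gives 1260 nM; compound 3 `CC(C)(C)c1ccc(OC(C)(C)C2OCC(C/C=C\CCC(=O)O)C(c3cccnc3)O2)cc1` gives 1910 nM, the highest of the three numbers, within the scatter of compound 2 and beyond it only against compound 1. Compound 4 `CC(C)(Oc1ccc(F)cc1[N+](=O)[O-])C1OCC(C/C=C\CCC(=O)O)C(c2cccnc2)O1` differs from compound 3 in one place: 4-fluoro-2-nitrophenyl in place of 4-(tert-butyl)phenyl on an oxygen on a saturated carbon. Among the measured compounds shown here, the single measured step, a 1.4-fold higher number from compound 1 to compound 2 (0.15 log units; within the scatter), exchanges a group on a saturated ring carbon and so does not bear on a change on an oxygen on a saturated carbon; nothing measured speaks to that place. Without precedent, no step beyond the scatter is expected, so a 1.0-fold lower number from compound 3 to compound 4 (0.00 log units; within the scatter) is the estimate. Compound 4 is expected at 1900 nM, with a range of 700 nM to 5000 nM.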

Compound 4, dissociation constant: 2.51 nM
The estimate for compound 4 lay 760-fold (2.88 log units) above the measured number; the whole stated range lies above it.
By their numbers in this assay, from the lowest: compound 4; then compounds 1, 2 and 3 (each within the scatter of the next, the first and the last beyond it).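

This place, an oxygen on a saturated carbon, proves highly sensitive in this assay: 4-fluoro-2-nitrophenyl in place of 4-(tert-butyl)phenyl gives a 760-fold lower number from compound 3 to compound 4 (2.88 log units; beyond the scatter) in a single exchange. Both groups have 10 heavy atoms and one six-membered aromatic ring of carbon only, so that count does not separate them. They differ in element make-up and in hydrogen-bond acceptors, 2 against 0.

On these data alone, whether the nitro group, the fluorine or the pair goes with the step stays open, as does the outcome with an amine in place of the nitro group. No available evidence bears on the cause of the step.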